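A few compounds are considered here, and "the series" means these few. Any claim that something is new, unique, unknown or untested is made for them only; others in the source may bear on it.

Measured so far: compound 1 `Cc1c(OCCCCOc2ccc(C(=O)O)cc2)ccc(C(=O)CC2CCCC2)c1O` with 26.7% and compound 2 `Cc1c(OCCCCOc2ccc(C(=O)O)cc2F)ccc(C(=O)CC2CCCC2)c1O` with 31.2% in an assay on HEK293 cells for positive allosteric modulation of metabotropic glutamate receptor 3 (Rattus norvegicus), read by thallium flux, with a stated time of 2.5 min; on this read-out lower numbers stand for smaller maximal responses and higher numbers for larger maximal responses.

Compound 2 stands within the usual scatter of compound 1 on this read-out, so the two numbers cannot be told apart. Going by the values given here, the one measured step, a number 4.5 percentage points higher from compound 1 to compound 2 (within the scatter), is the only step that bears on the change now at hand, and it lies within the scatter.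

Compound 3 `Cc1c(OCCCCOc2ccc(C(=O)O)cc2Cl)ccc(C(=O)CC2CCCC2)c1O` differs from compound 2 by chloro in place of fluoro on an aromatic carbon. Among the compounds with values here, the one comparable step, a number 4.5 percentage points higher from compound 1 to compound 2 (within the scatter), gives no sign that exchanging one halogen for another on this aromatic carbon moves the maximal response beyond the scatter, and nothing else is known about the chloro group here. The account therefore expects for compound 3 a step of about a number 0.8 percentage points higher from compound 2 to compound 3 (within the scatter), that is, no change beyond the scatter.

The maximal response of compound 3 is estimated at 32%, expected to fall between 18% and 46%.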

Compound 3, largest response reached (reported as percent of maximum), in percent of the reference or control that the assay uses: 27.4%
Beside the measured number, compound 3's estimate is 4.6 percentage points above it; the range from low to high includes it.
By their numbers in this assay, from the lowest: compounds 1, 3 and 2 (each within the scatter of the next).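

In this assay, chloro in place of fluoro on the aromatic carbon ortho to a large group and meta to a carboxy group gives a number 3.8 percentage points lower from compound 2 to compound 3 (within the scatter), while chloro in place of hydrogen on that carbon gives a number 0.7 percentage points higher from compound 1 to compound 3 (within the scatter). Going by these compounds alone, with hydrogen, fluoro and chloro now compared on this carbon, neither halogen shifts the maximal response beyond the scatter, a finding that the single fluoro step could not extend beyond one halogen. Nothing measured here offers an explanation for this result.

On these data alone, whether a different group on this carbon, such as methoxy, trifluoromethyl or an amine, would move the maximal response beyond the scatter remains open. Also open, as far as these compounds go, is whether changes elsewhere in the molecule, such as a longer chain between the two oxygen atoms, would do so.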